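This account rests on a few compounds, and the source may have more. Where it says the series, first, only, none or still open, it means among the compounds named here.

In a functional assay on SK-HEP1 cells (Homo sapiens) for inhibition, read by MTT assay, with a stated time of 72 h (a lower number here means a stronger inhibitor, a higher number a weaker inhibitor), compound 1 `CNC(=O)CCCCCCCn1nc(-c2cnc3[nH]ccc3c2)c2c(N)ncnc21` gives 3950 nM. Compound 2 `Nc1nc2cc(-c3nn(CCCCCCCCC(=O)NO)c4ncnc(N)c34)ccc2o1` gives > 100000 nM, which is a limit and not a number, and it stands at the limit of > 100000 nM in this assay, at which 1 of the 2 values shown sits. Compound 3 `CNC(=O)CCCCCCCn1nc(-c2ccc3oc(N)nc3c2)c2c(N)ncnc21` carries methylcarbamoyl in place of (hydroxycarbamoyl)methyl on a saturated chain carbon, seven bonds along the chain from an aromatic nitrogen. Going by the values given here, no measured step covers this change, so the expectation in this assay is a move toward stronger inhibition, resting only on compound 1 at 3950 nM. The expected size is an at least 10-fold lower number from compound 2 to compound 3 (1.00 log units; beyond the scatter). For compound 3 the estimated value is 10000 nM, with an expected range of 2000 nM to 60000 nM.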

Compound 3, half-maximal inhibitory concentration: 10700 nM
For compound 3 the middle estimate is 1.1-fold (0.03 log units) below the measured one, within the range that was stated.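

In this assay, compound 2 stands at a limit and not at a number: the limit of > 100000 nM in this assay, at which 1 of the 3 values shown sits. Methylcarbamoyl in place of (hydroxycarbamoyl)methyl, on a saturated chain carbon, seven bonds along the chain from an aromatic nitrogen, gives an at least 9.3-fold lower number from compound 2 to compound 3 (0.97 log units; beyond the scatter) and so brings this series into the readable range. With that chain end held, the change of aromatic group on an aromatic carbon gives a 2.7-fold higher number from compound 1 to compound 3 (0.43 log units; beyond the scatter) and shows that this second place also moves the number.

Open, going by these compounds, are a carboxylic acid or a primary amide at the chain end. On these data alone, a longer chain carrying methylcarbamoyl also remains open.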